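Methoxy in Place of Chloro: Estimating Compound 3

The source may hold more compounds than are shown below. What is called first, only, known or untested is meant among the compounds shown, and "the series" means these compounds.

Measured compounds:
compound 1 `Cc1nc(-c2ccc(Cl)cc2)sc1C(=O)CSc1nc(-c2ccccc2)c(C#N)c(=O)[nH]1`: 41.6%
compound 2 `COc1ccc(-c2nc(SCC(=O)c3sc(-c4ccc(Cl)cc4)nc3C)[nH]c(=O)c2C#N)cc1OC`: 59.8%

In a functional assay on U-87MG ATCC cells for antiproliferative activity against U-87 MG (Homo sapiens), read by MTT assay, with a stated time of 48 h, tested at 50 uM (a lower number here means a stronger effect, a higher number a weaker effect of the compound at the concentration tested), compound 1 gives 41.6%, the lowest of the two numbers shown. Among the compounds with values here, compound 2 gives 59.8%, and the one measured step, a number 18.2 percentage points higher from compound 1 to compound 2 (beyond the scatter), covers that gap. Compound 3 `COc1ccc(-c2nc(C)c(C(=O)CSc3nc(-c4ccccc4)c(C#N)c(=O)[nH]3)s2)cc1` differs from compound 1 in one place: methoxy in place of chloro on an aromatic carbon. Within the data shown here, no measured step touches this change. Among the measured compounds shown here, the only step known, a number 18.2 percentage points higher from compound 1 to compound 2 (beyond the scatter), swaps phenyl for 3,4-dimethoxyphenyl and leaves the chloro untouched, so it does not bear directly on the methoxy-for-chloro change, though it shows that adding methoxy groups elsewhere went with a higher number. For the measured compounds named here, with no direct precedent, compound 3 is expected to stay close to compound 1, a step of a number 6.4 percentage points higher from compound 1 to compound 3 (within the scatter) that is expected to fall within the scatter or only slightly beyond it, if anything toward a higher number. The estimate for compound 3 is 48%, with a range from 33% to 63%.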

Compound 3, a percentage reported as activity, at one concentration (the size of the read-out at that concentration, not a potency): 72.5%
For compound 3 the middle estimate is 24.5 percentage points below the measured one; the whole stated range lies below it.
By their numbers in this assay, from the lowest: compound 1; then compound 2; then compound 3.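

In this assay, the change from 4-chlorophenyl to 4-methoxyphenyl on the core of compound 1 gives a number 30.9 percentage points higher from compound 1 to compound 3 (beyond the scatter), so this place on the ring is not indifferent to what it carries, and here chloro goes with the stronger effect at the concentration tested. Within the data shown here, the only earlier step, a number 18.2 percentage points higher from compound 1 to compound 2 (beyond the scatter), lay at another place and left the chloro untouched, so together the two steps show that methoxy goes with a higher number at both places. Nothing measured here explains why the swap has this effect.

The compounds shown leave open whether the higher number comes from losing chloro or from gaining methoxy. An unsubstituted phenyl, or a fluoro or amino group at this place, would help separate the two.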